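The compounds below may be only part of what the source reports. "The series", "measured", "known", "first", "only" and "open" are said of these compounds alone.

Values in an ADME assay on HepG2 cells (Homo sapiens) for inhibition, read by fluorescence and resazurin assay, with a stated time of 72 h; a higher number here means a weaker inhibitor, a lower number a stronger inhibitor:
- compound 1 `NS(=O)(=O)c1ccc(Nc2nccc(Nc3ccc4nc[nH]c4c3)n2)cc1`: > 25000 nM (a limit)
- compound 2 `NS(=O)(=O)c1ccc(Nc2ncc(Cl)c(Nc3ccc4nc[nH]c4c3)n2)cc1`: 7800 nM
- compound 3 `NC(=O)c1ccc(Nc2nccc(Nc3ccc4cn[nH]c4c3)n2)cc1`: 16000 nM

Compound 1 gives only a limit, > 25000 nM. Of the two actual numbers, compound 2 at 7800 nM is the lower, and compound 3 at 16000 nM is the higher.

Next in the series is compound 4 `Cc1cnc(Nc2ccc(S(N)(=O)=O)cc2)nc1Nc1ccc2nc[nH]c2c1`, still unmeasured. It has methyl in place of chloro on an aromatic carbon of a six-membered aromatic ring with 2 nitrogen: methyl in place of chloro on an aromatic carbon.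

Among the measured compounds shown here, one measured step bears on this change: an at least 3.2-fold lower number from compound 1 to compound 2 (0.50 log units; beyond the scatter), with chloro in place of hydrogen on that same aromatic carbon. For the measured compounds named here, no measured compound carries methyl there, so this single step is a limited guide. Going by that step, and by compound 2 at 7800 nM, part of the step is expected to be lost once chloro leaves, giving a modest move to a higher number in this assay. The estimate implies a 2.1-fold higher number from compound 2 to compound 4 (0.31 log units; beyond the scatter), an expected step close to the edge of the scatter. A result for compound 4 could also come back only as a limit, as in the limit of > 25000 nM in this assay, at which 1 of the 3 values shown sits.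

For compound 4 the estimated value is 16000 nM, with an expected range from 7000 nM to 25000 nM.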

Compound 4, half-maximal inhibitory concentration: 18000 nM
Estimate against measurement, compound 4: 1.1-fold (0.05 log units) below, within the range that was stated.
By their numbers in this assay, from the lowest: compound 2; then compounds 3 and 4 (each within the scatter of the next). At a limit, above all of these: compound 1.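

In this assay, methyl in place of chloro on an aromatic carbon gives a modest step: a 2.3-fold higher number from compound 2 to compound 4 (0.36 log units; beyond the scatter). The earlier compounds shown here showed only the effect of replacing hydrogen with chloro, an at least 3.2-fold lower number from compound 1 to compound 2 (0.50 log units; beyond the scatter), whereas this pair shows that the lower number does not carry over from chloro to methyl, although each group has one heavy atom on the same carbon. Methyl in place of hydrogen on this carbon gives an at least 1.3-fold lower number from compound 1 to compound 4 (0.14 log units; that floor lies within the scatter). The full size of that step cannot be read, because compound 1 gives only a limit: the limit of > 25000 nM in this assay, at which 1 of the 4 values shown sits.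

Whether the lower number is particular to chloro stays open, since the compounds shown have no fluoro, bromo, methoxy, nitrile or amine on this carbon to set beside chloro and methyl. Chloro and methyl are also compared only on the core of compound 1, so it remains open whether the same steps would appear on the core of compound 3, which has hydrogen at this position.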